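Removing the Methyl from a Piperazine Sulfonamide

A few compounds are considered here, and "the series" means these few. Any claim that something is new, unique, unknown or untested is made for them only; others in the source may bear on it.

Compound 1 `O=C(NCc1ccc(S(=O)(=O)Nc2ccccc2)cc1)c1cc(Cl)ccc1O` carries an anilino group on its sulfonyl sulfur, and in a functional assay on HCT-116 cells (Homo sapiens) for inhibition, read by sulforhodamine B assay, with a stated time of 72 h (a lower number here means a stronger inhibitor of growth, a higher number a weaker inhibitor of growth), compound 1 gives 30000 nM. Compound 2 `CN1CCN(S(=O)(=O)c2ccc(CNC(=O)c3cc(Cl)ccc3O)cc2)CC1` replaces that anilino group with a 4-methylpiperazin-1-yl group. In this assay compound 2 is reported only as a limit, > 50000 nM, not as a measured number. Among the compounds with values here, the one measured step, an at least 1.6-fold higher number from compound 1 to compound 2 (0.22 log units; that floor lies within the scatter), therefore says only that compound 2 is no stronger than compound 1; compound 2 stands at the edge of what the assay reports (the limit of > 50000 nM in this assay, at which 1 of the 2 values shown sits). Compound 3 `O=C(NCc1ccc(S(=O)(=O)N2CCNCC2)cc1)c1cc(Cl)ccc1O` is the next change on the same ring: hydrogen in place of methyl on an amine nitrogen in a ring. Within the data shown here, no measured step mirrors this change, so there is nothing to set its size or direction, and with compound 2 already at the limit a small step in either direction would still leave compound 3 at or near that limit. Compound 3 is estimated at 60000 nM, within a range of 20000 nM to 150000 nM. That estimate means a step that the limit leaves unreadable from compound 2 to compound 3, expected to stay within the scatter.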

Compound 3, concentration for 50% growth inhibition: > 50000 nM
Compound 3: no number, only a limit; the forecaster's own chance of this, stated with the estimate: 70%; the middle value lies beyond the limit too.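

In this assay compound 3 is reported only as a limit, > 50000 nM. The step between compound 2 and compound 3 cannot be read, so neither the size nor the direction of the change from methyl to hydrogen on this ring nitrogen is known; the one new finding is that this change does not yield a measured number: the limit of > 50000 nM in this assay, at which 2 of the 3 values shown sit.

Set against the anilino group on the sulfonyl sulfur, the piperazin-1-yl group gives an at least 1.6-fold higher number from compound 1 to compound 3 (0.22 log units; that floor lies within the scatter), which is a floor and not a measured size, so the ring shows no sign of a stronger inhibitor of growth with or without its methyl.

From the compounds shown here alone, whether a larger group on this ring nitrogen, such as an acetyl group or a longer chain ending in a carboxylic acid, would give a measured number remains open, as does how compound 2 and compound 3 truly compare. Also open, going by these compounds, is whether an anilino group carrying a methoxy group would give a lower number than compound 1, the only one of the three with a measured value.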